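The source may hold more compounds than are shown below. What is called first, only, known or untested is meant among the compounds shown, and "the series" means these compounds.

Compound 1 `CC(C)(C)c1ccc(N/C(S)=N/Cc2ccc(NS(C)(=O)=O)c(F)c2)cc1` and compound 2 `CCCc1ccc(C/N=C(\S)NCc2ccc(NS(C)(=O)=O)c(F)c2)cc1` share the same core, and they differ in the part that carries the outer aromatic ring. In an assay for inhibition of transient receptor potential cation channel subfamily V member 1 (Rattus norvegicus), with a stated time of 10 min (on this read-out higher numbers stand for weaker inhibition and lower numbers for stronger inhibition), compound 1 gives 1600 nM. In this assay compound 2 gives 460 nM, the lower of the two numbers obtained so far; its nearest neighbour is compound 1, whose number sits beyond the usual scatter of the assay. Compound 3 `CC(C)c1ccc(C/N=C(\S)NCc2ccc(NS(C)(=O)=O)c(F)c2)cc1` is built from compound 2 by a single change, (isopropyl in place of propyl on an aromatic carbon), so the two have the same atoms, joined differently.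

Among the measured compounds shown here, no pair of measured compounds shows the effect of this kind of change, so the expectation rests on compound 2 alone. With the group keeping all of its atoms and only their arrangement changing, the step from compound 2 to compound 3 is expected to be a 1.1-fold higher number from compound 2 to compound 3 (0.04 log units; within the scatter), a move that need not rise above the scatter in either direction. Compound 3 is therefore expected to give about 500 nM in this assay, with a likely range from 200 nM to 1300 nM.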

Compound 3, half-maximal inhibitory concentration: 520 nM
For compound 3 the middle estimate is 1.0-fold (0.02 log units) below the measured one; the range from low to high includes it.
By their numbers in this assay, from the lowest: compounds 2 and 3 (each within the scatter of the next); then compound 1.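

In this assay, replacing propyl with isopropyl on the aromatic carbon para to a large group gives a 1.1-fold higher number from compound 2 to compound 3 (0.05 log units; within the scatter) and so leaves the two compounds indistinguishable on this read-out. Among the compounds shown here, this is the only step here between measured compounds that differ in one place, and it adds what a single compound could not show: at this position, the same three carbons can be rearranged from propyl to isopropyl without a change that rises above the scatter. Nothing available explains this result, so the data record the outcome without giving a reason for it.

A single pair at a single position cannot show whether other groups placed there, such as a longer chain like hexyl, a methoxy group or a carboxylic acid, would shift the number beyond the scatter, so the tolerance seen here may not extend to them. Compound 1 carries tert-butyl on its outer ring but also differs from compound 2 and compound 3 in how that ring is attached, which leaves the contribution of tert-butyl itself unresolved.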